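Tetrahydroisoquinoline amide of the nitro-sulfone series: cytotoxicity outlook

A few compounds are considered here, and "the series" means these few. Any claim that something is new, unique, unknown or untested is made for them only; others in the source may bear on it.

Three amides built on the shared core of compound 1 have been tested in an ADME assay on HepG2 cells (Homo sapiens) for cytotoxicity, read by CellTiter-Glo and ATP content, with a stated time of 72 h; a lower number here means that less compound is needed, a higher number that more compound is needed for the effect. Compound 1 `CS(=O)(=O)c1ccc(C(=O)NCCC(=O)N2CCCCC2)cc1[N+](=O)[O-]` sits at the limit of > 27000 nM, which is a limit of the assay rather than a number. Compound 2 `CC1CCN(C(=O)CCNC(=O)c2ccc(S(C)(=O)=O)c([N+](=O)[O-])c2)CC1` likewise reaches only the limit of > 27000 nM in this assay. Compound 3 `CC(C)N(C(=O)CCNC(=O)c1ccc(S(C)(=O)=O)c([N+](=O)[O-])c1)C(C)C` also gives just the limit of > 27000 nM in this assay. Accordingly the steps between them are unreadable: a step that the two limits leave unreadable from compound 1 to compound 2, a step that the two limits leave unreadable from compound 1 to compound 3 and a step that the two limits leave unreadable from compound 2 to compound 3. The common feature is the limit of > 27000 nM in this assay, at which 3 of the 3 values shown sit, so compound 3 stands where every compound of this set stands, at the limit in this assay.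

Compound 4 `CS(=O)(=O)c1ccc(C(=O)NCCC(=O)N2CCc3ccccc3C2)cc1[N+](=O)[O-]` differs from compound 3 by 1,2,3,4-tetrahydroisoquinolin-2-yl in place of diisopropylamino on a carbonyl carbon. All three measured steps bear on this change of the amine on the carbonyl carbon, and none of them was readable, because the limit of > 27000 nM in this assay, at which 3 of the 3 values shown sit, caps all of them. No step beyond the scatter is therefore expected in this assay in either direction, and compound 4 is expected to remain at the limit as well, a step that the limit leaves unreadable from compound 3 to compound 4. Compound 4 is estimated at 40000 nM, within a range from 15000 nM to 120000 nM.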

Compound 4, half-maximal effective concentration: > 27000 nM
Compound 4 gave a limit, no number; the forecaster's own chance of this, stated with the estimate: 85%; the middle value lies beyond the limit too.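

The steps from compound 1, compound 2 and compound 3 to compound 4 cannot be read in this assay because all four compounds give only a limit of the assay and no number: the limit of > 27000 nM in this assay, at which 4 of the 4 values shown sit. The compounds shown leave open at what concentration any of them would produce the effect, and whether the amine on the carbonyl carbon alters that concentration.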